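Notes on replacing the aryl group of compound 2

The source may hold more compounds than are shown below. What is called first, only, known or untested is meant among the compounds shown, and "the series" means these compounds.

Within the data shown here, compound 2 `COc1cccc(-n2cc(COc3cccc(NC(=O)Nc4ccc(Cl)c(C(F)(F)F)c4)c3)nn2)c1` gives 1310 nM in a functional assay on HepG2 cells (Homo sapiens) for inhibition, read by MTT assay, with a stated time of 72 h (a lower number here means a stronger inhibitor, a higher number a weaker inhibitor), the lowest number of the three so far, though its gap to compound 1 lies within the scatter. Compound 1 `O=C(Nc1cccc(OCc2cn(-c3ccccc3)nn2)c1)Nc1ccc(Cl)c(C(F)(F)F)c1` gives 1780 nM, and a 1.4-fold lower number from compound 1 to compound 2 (0.13 log units; within the scatter). Compound 3 `Cc1cccc(-n2cc(COc3cccc(NC(=O)Nc4ccc(Cl)c(C(F)(F)F)c4)c3)nn2)c1` gives 7270 nM; a 5.5-fold higher number from compound 2 to compound 3 (0.74 log units; beyond the scatter) and a 4.1-fold higher number from compound 1 to compound 3 (0.61 log units; beyond the scatter). Compound 4 `N#Cc1ccccc1-n1cc(COc2cccc(NC(=O)Nc3ccc(Cl)c(C(F)(F)F)c3)c2)nn1` carries 2-cyanophenyl in place of 3-methoxyphenyl on an aromatic nitrogen. Among the measured compounds shown here, no measured step involves a nitrile on this ring; the only recorded swap there, methyl for methoxy, moved the number beyond the scatter. On these data alone, how that bears on the nitrile is unknown, so a step of modest size in either direction, or none beyond the scatter, is expected in this assay. Compound 4 is estimated at 2000 nM, between 800 nM and 6000 nM, an expected 1.5-fold higher number from compound 2 to compound 4 (0.18 log units; within the scatter).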

Compound 4, half-maximal inhibitory concentration: 1970 nM
Compound 4: the middle estimate sits 1.0-fold (0.01 log units) above what was measured; the range from low to high includes it.
By their numbers in this assay, from the lowest: compounds 2, 1 and 4 (each within the scatter of the next); then compound 3.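

With 2-cyanophenyl on the aromatic nitrogen, this assay shows no separation from either the hydrogen of compound 1 (a 1.1-fold higher number from compound 1 to compound 4 (0.04 log units; within the scatter)) or the 3-methoxyphenyl of compound 2 (a 1.5-fold higher number from compound 2 to compound 4 (0.18 log units; within the scatter)). The step from 3-methylphenyl (a 3.7-fold lower number from compound 3 to compound 4 (0.57 log units; beyond the scatter)) leaves compound 3 as the only one of the four set apart from the others. No supporting measurement is available to explain this pattern.

On these data alone, what an amine or a carboxylic acid on this aryl ring would do remains open.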